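Estimating stability when the closest compound has no number

The compounds below may be only part of what the source reports. "The series", "measured", "known", "first", "only" and "open" are said of these compounds alone.

Compound 3 `O=C(N1CC[C@](c2ccc(C(F)(C(F)(F)F)C(F)(F)F)cc2)(S(=O)(=O)c2ccc(F)cc2)C1)C12CCC(C(=O)O)(CC1)OC2` gives no starting point: in an ADME assay on microsomes from liver (Homo sapiens) for metabolic stability, with a stated time of 10 min (on this read-out lower numbers stand for a less stable compound and higher numbers for a more stable compound), compound 3 has the entry "not determined" (no result reported) and so offers no number to compare with. Compound 4 `NC(=O)[C@H]1CC[C@H](C(=O)N2CC[C@](c3ccc(C(F)(C(F)(F)F)C(F)(F)F)cc3)(S(=O)(=O)c3ccc(F)cc3)C2)CC1` differs from it in one place: a group of 9 heavy atoms (7 carbon, 1 nitrogen, 1 oxygen; one six-membered non-aromatic ring of carbon only) in place of a group of 11 heavy atoms (8 carbon, 3 oxygen; one six-membered non-aromatic ring of carbon only, one six-membered non-aromatic ring with 1 hetero atom), on a carbonyl carbon and the group that enters is 4-carbamoylcyclohexyl, while the shared core stays the same.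

The nearest measured evidence comes from two other compounds. Compound 1 `C[C@]1(C(=O)O)CC[C@H](C(=O)N2CC[C@](c3ccc(C(F)(C(F)(F)F)C(F)(F)F)cc3)(S(=O)(=O)c3ccc(F)cc3)C2)CC1` gives 97% in this assay and compound 2 `C[C@]1(C(=O)N2CC[C@](c3ccc(C(F)(C(F)(F)F)C(F)(F)F)cc3)(S(=O)(=O)c3ccc(F)cc3)C2)CC[C@H](C(=O)O)CC1` gives 80% on the same read-out. Within the data shown here, the one measured step, also a change in the group on a carbonyl carbon, is a number 17 percentage points lower from compound 1 to compound 2 (beyond the scatter) and it offers the only guide to how far the read-out can move with such a change. Among the measured compounds shown here, no measured compound carries the 4-carbamoylcyclohexyl group, so that step only loosely bears on this swap.

With no value for compound 3, no size or direction of step can be expected in this assay for this change. The expectation instead rests on the level set by compound 2 at 80% and compound 1 at 97% with a wide margin added. Compound 4 is expected to give about 80% with an estimated range from 55% to 98% in this measurement.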

Compound 4, percent of the compound remaining: 100%
Estimate against measurement, compound 4: 20 percentage points below; measured number outside the range, above it.
By their numbers in this assay, from the lowest: compound 2; then compounds 1 and 4 (each within the scatter of the next).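

The position on the carbonyl carbon does not need a carboxy group or a methyl group to give a high number: compound 4 has neither and reaches 100% in this assay. Its 4-carbamoylcyclohexyl group gives a number 20 percentage points higher from compound 2 to compound 4 (beyond the scatter), so this group stands clearly apart from the 4-carboxy-1-methylcyclohexyl group, while against the 4-carboxy-4-methylcyclohexyl group it gives a number 3 percentage points higher from compound 1 to compound 4 (within the scatter), which places these two groups level on this read-out. Nothing among the data shown accounts for either result.

As far as these compounds go, compound 3 has no number, so the swap from its group to 4-carbamoylcyclohexyl cannot be read, and the effect of replacing that group on the carbonyl carbon remains unknown. Also open, from the compounds shown here alone, is whether the number would hold with an amine or a nitrile at the same place on the cyclohexyl ring in place of the carbamoyl group, or with a simple carboxylic acid on a cyclohexyl ring that carries no methyl group, which would separate the contribution of the methyl group from that of the carboxy group.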